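The source may report more compounds than this note shows. Statements on the series, on what has been measured and on what is new or still open speak of the compounds shown alone.

Measured compounds and their values:

Compound 1 `O=C(NC1CCCCC1)c1cc(Oc2ccc(/C=C/c3ccccn3)cc2)ccn1` gives 20600 nM in a functional assay on HepG2 cells (Homo sapiens) for antiproliferative activity, read by CCK-8 assay, with a stated time of 48 h; a higher number here means a weaker inhibitor, a lower number a stronger inhibitor.
Compound 2 `O=C(c1cc(Oc2ccc(/C=C/c3ccccn3)cc2)ccn1)N1CCCC1` gives 27000 nM in this assay.
Compound 3 `O=C(NC1CCCCC1)c1cc(Oc2ccc(/C=C/c3ccncc3)cc2)ccn1` gives 22400 nM in this assay.

Compound 4 `O=C(c1cc(Oc2ccc(/C=C/c3ccncc3)cc2)ccn1)N1CCCC1` has not yet been measured in this assay. It relates to compound 3 the way compound 2 relates to compound 1: the change is pyrrolidin-1-yl in place of cyclohexylamino on a carbonyl carbon. The same change, (pyrrolidin-1-yl in place of cyclohexylamino on a carbonyl carbon), has already been made once, and it gave a 1.3-fold higher number from compound 1 to compound 2 (0.12 log units; within the scatter). The two places are described in the same words, so this is the same change on a different core. The cores of compound 3 and compound 1 differ by pyridin-4-yl in place of pyridin-2-yl on a double-bonded chain carbon bound to a double-bonded chain carbon, and that difference gave a 1.1-fold higher number from compound 1 to compound 3 (0.04 log units; within the scatter), so all three measured compounds sit close together.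

Within the data shown here, for compound 4 the step is expected to be a 1.3-fold higher number from compound 3 to compound 4 (0.11 log units; within the scatter), beside the earlier step, because the earlier step of a 1.3-fold higher number from compound 1 to compound 2 (0.12 log units; within the scatter) was small and the change is the same; this rests on only one prior example. Compound 4 is therefore estimated at 29000 nM, with a range from 15000 nM to 56000 nM.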

Compound 4, half-maximal inhibitory concentration: 41600 nM
The estimate for compound 4 lay 1.4-fold (0.16 log units) below the measured number; low and high end bracket the measured number.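

In this assay, pyrrolidin-1-yl in place of cyclohexylamino on the carbonyl carbon gives a 1.9-fold higher number from compound 3 to compound 4 (0.27 log units; within the scatter), and pyridin-4-yl in place of pyridin-2-yl gives a 1.5-fold higher number from compound 2 to compound 4 (0.19 log units; within the scatter). The first change reads the same on both cores, as far as two pairs can tell: the same change on two cores in this assay, a 1.3-fold higher number (0.12 log units; within the scatter) from compound 1 to compound 2 and a 1.9-fold higher number (0.27 log units; within the scatter) from compound 3 to compound 4, 1.4-fold (0.15 log units) apart, within the scatter of two such steps. The pyridine change also carries over, but every one of these steps lies within the scatter, so the data cannot show that either change really moves the number, and two cores are too few to make a rule: the same change on two cores in this assay, a 1.1-fold higher number (0.04 log units; within the scatter) from compound 1 to compound 3 and a 1.5-fold higher number (0.19 log units; within the scatter) from compound 2 to compound 4, 1.4-fold (0.15 log units) apart, within the scatter of two such steps.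

The compounds shown leave open whether a carboxylic acid on the carbonyl carbon, or a piperidin-1-yl group or a longer chain on the amide nitrogen, would give a step beyond the scatter. Also open is whether a pyridin-3-yl group would differ from the two pyridines shown, and whether either change would behave the same way on a third core.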